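Formyl to Propanoyl on a Nitrophenyl Carboxamide Ester

The source may hold more compounds than are shown below. What is called first, only, known or untested is meant among the compounds shown, and "the series" means these compounds.

Three compounds share a core and differ only in the ester attached to it. Compound 1 `Cc1ccc(C(=O)OC2(C(=O)Nc3ccc([N+](=O)[O-])cc3)CCCCC2)cc1` gives 45.4 nM in a functional assay on NFS-60 cells (Mus musculus) for inhibition, read by MTT assay, with a stated time of 72 h; a lower number here means a stronger inhibitor, a higher number a weaker inhibitor. Compound 2 `O=C(OC1(C(=O)Nc2ccc([N+](=O)[O-])cc2)CCCCC1)c1ccccc1` gives 766 nM in the same assay, and compound 3 `O=COC1(C(=O)Nc2ccc([N+](=O)[O-])cc2)CCCCC1` gives 33.8 nM. Compound 3 has the lowest number of the three; its number and that of compound 1 lie within the scatter of each other, while a 23-fold lower number from compound 2 to compound 3 (1.36 log units; beyond the scatter).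

Compound 4 `CCC(=O)OC1(C(=O)Nc2ccc([N+](=O)[O-])cc2)CCCCC1` has not yet been measured. The change from compound 3 to compound 4 is ethyl in place of hydrogen on a carbonyl carbon. For the measured compounds named here, two measured steps bear on this position of the ester: a 1.3-fold lower number from compound 1 to compound 3 (0.13 log units; within the scatter), and a 23-fold lower number from compound 2 to compound 3 (1.36 log units; beyond the scatter). Both replace an aryl group with hydrogen; one is neutral and the other is large. Compound 4 instead carries an ethyl group, with no ring, which is much closer in size to hydrogen than either aryl group. The account therefore expects no step beyond the scatter, at most a modest drift to a higher number: a 1.5-fold higher number from compound 3 to compound 4 (0.17 log units; within the scatter) is the expected step. The estimate for compound 4 is accordingly 50 nM, with a range from 15 nM to 160 nM.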

Compound 4, half-maximal inhibitory concentration: 6.4 nM
Beside the measured number, compound 4's estimate is 7.8-fold (0.89 log units) above it, and the stated range ends above it.
By their numbers in this assay, from the lowest: compound 4; then compounds 3 and 1 (each within the scatter of the next); then compound 2.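

In this assay, for the compounds shown here, the propanoyl ester gives a 5.3-fold lower number from compound 3 to compound 4 (0.72 log units; beyond the scatter) and so shows something the earlier compounds did not: a group on this carbonyl carbon can give a number lower than hydrogen does, by a margin beyond the scatter. Until now, the only replacements for hydrogen at this position were the two aryl groups, and neither gave such a gain, as 4-methylphenyl stayed within the scatter of hydrogen and phenyl gave a much higher number. Ethyl also separates from both aryl groups, with a 7.1-fold lower number from compound 1 to compound 4 (0.85 log units; beyond the scatter) and a 120-fold lower number from compound 2 to compound 4 (2.08 log units; beyond the scatter) making compound 4 the strongest inhibitor of the four, though no measurement shown gives a reason for this gain.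

The compounds shown leave open how the number responds to the size and shape of an open chain at this carbonyl carbon, since only ethyl represents such chains here. Methyl, giving the acetyl ester, a longer chain such as propyl, a branched isopropyl group and a small ring such as cyclopropyl would each show whether ethyl is a peak or one point along a wider range.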